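The compounds below may be only part of what the source reports. "The series", "measured", "known", "first", "only" and "open" are said of these compounds alone.

The measured compounds are:
compound 1, `COc1cc(OC)c(OC)cc1/C=C/COC(=O)/C=C/c1ccc(OC)c(OC)c1`, with 0%;
compound 2, `COc1cc(OC)c(OC)cc1/C=C/COC(=O)/C=C/c1cccc(Br)c1`, with 25%.

In a functional assay on the whole organism (strain Kunming) with Mus musculus as the target, with a stated time of 0.5 h, at a dose of 300 mg/kg by the intraperitoneal route (a higher number here means a weaker effect of the compound at the dose given, a lower number a stronger effect), compound 1 gives 0%, and compound 2 gives 25%. Compound 2 therefore holds the higher of the two numbers, and its nearest neighbour, compound 1, lies beyond the scatter from it. Among the measured compounds shown here, the only step between measured compounds, a number 25 percentage points higher from compound 1 to compound 2 (beyond the scatter), is modest in size.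

Compound 3, `COc1cc(OC)c(OC)cc1/C=C/COC(=O)/C=C/c1ccc(F)cc1`, has not yet been measured in this assay. It differs from compound 2 in that (4-fluorophenyl in place of 3-bromophenyl on a double-bonded chain carbon bound to a double-bonded chain carbon). The step from compound 1 to compound 2 is the only one that touches the same place in the molecule; it shows that exchanging the aryl group on that chain carbon can shift the number by a modest amount. For the measured compounds named here, no measured pair exchanges one halogen-bearing phenyl for another, so the present change has no direct precedent in the data. Compound 3 is therefore expected to stay close to compound 2, with an estimated step of a number 5 percentage points lower from compound 2 to compound 3 (within the scatter), inside the usual scatter. Compound 3 is estimated at 20%, with a range from 0% to 45%.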

Compound 3, a percentage reported as activity, at one dose (the size of the read-out at that dose, not a potency): 0%
Compound 3: middle estimate off by 20 percentage points, on the high side, within the range that was stated.
By their numbers in this assay, from the lowest: compounds 1 and 3 (each within the scatter of the next); then compound 2.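

In this assay, exchanging one halogen-bearing phenyl for another gives a number 25 percentage points lower from compound 2 to compound 3 (beyond the scatter) and so shows that a halogen on the phenyl at this double-bonded chain carbon does not by itself fix the number: 3-bromophenyl and 4-fluorophenyl are not equivalent here. The second comparison, no change at the digits printed from compound 1 to compound 3 (within the scatter) in the same read-out, places 4-fluorophenyl level with 3,4-dimethoxyphenyl, so two quite differently substituted phenyl groups give the same reading and, among these three compounds, only compound 2 with its 3-bromophenyl stands apart. Nothing available explains why the two halogen-bearing groups part ways.

The exchange from 3-bromophenyl to 4-fluorophenyl alters both the halogen and where it stands on the phenyl, so these compounds cannot say which of the two matters; 4-bromophenyl and 3-fluorophenyl would separate them. They also leave open how this place responds to a phenyl carrying an amine or a carboxylic acid, or to a non-aromatic group such as a longer alkyl chain in place of the phenyl.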